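Changing the chain on the sulfonyl sulfur

The source may hold more compounds than are shown below. What is called first, only, known or untested is meant among the compounds shown, and "the series" means these compounds.

Compound 1 `CC(C)(C)OC(=O)NCCS(=O)(=O)NC(=O)c1ccc(Nc2nc(NC3(c4ccc(Cl)cc4)CC3)nc(OCC(F)(F)F)n2)cc1` is measured in an ADME assay on microsomes from liver (Rattus norvegicus) for metabolic stability, with a stated time of 10 min (on this read-out lower numbers stand for a less stable compound and higher numbers for a more stable compound), where compound 1 gives 93%. Its nearest neighbour is compound 2 `CC(C)S(=O)(=O)NC(=O)c1ccc(Nc2nc(NC3(c4ccc(Cl)cc4)CC3)nc(OCC(F)(F)F)n2)cc1`, which gives 96%, and its furthest is compound 3 `CC(=O)NCCS(=O)(=O)NC(=O)c1ccc(Nc2nc(NC3(c4ccc(Cl)cc4)CC3)nc(OCC(F)(F)F)n2)cc1`, which gives 100%. All steps among them stay within the scatter: a number 3 percentage points higher from compound 1 to compound 2 (within the scatter), a number 7 percentage points higher from compound 1 to compound 3 (within the scatter) and a number 4 percentage points higher from compound 2 to compound 3 (within the scatter). Compound 4 `O=C(NS(=O)(=O)CCNCc1ccccc1)c1ccc(Nc2nc(NC3(c4ccc(Cl)cc4)CC3)nc(OCC(F)(F)F)n2)cc1` differs from compound 1 in one place: benzyl in place of tert-butoxycarbonyl on an amine nitrogen. The step from compound 1 to compound 3, which also alters the group attached to that amine nitrogen, bears most directly on this change, and it was small. A step of similar size is therefore expected, a number 3 percentage points lower from compound 1 to compound 4 (within the scatter), with no shift beyond the scatter. For compound 4 the estimate is 90%, between 72% and 100%.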

Compound 4, percent of the compound remaining: 100%
For compound 4 the middle estimate is 10 percentage points below the measured one, within the range that was stated.
By their numbers in this assay, from the lowest: compounds 1, 2, 3 and 4 (each within the scatter of the next).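

On the amine nitrogen, benzyl, with its six-membered aromatic ring of carbon only, stands in for tert-butoxycarbonyl (a number 7 percentage points higher from compound 1 to compound 4 (within the scatter)) and for acetyl (no change at the digits printed from compound 3 to compound 4 (within the scatter)) without leaving the scatter in this assay. Replacing isopropyl on the sulfonyl sulfur with the whole 2-(benzylamino)ethyl chain also stays within it (a number 4 percentage points higher from compound 2 to compound 4 (within the scatter)). Nothing available gives a reason for this result. Still open, from the compounds shown here alone, is whether an unsubstituted amine, a carboxylic acid at the end of the chain, or a longer chain would move this number beyond the scatter.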